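A few compounds are considered here, and "the series" means these few. Any claim that something is new, unique, unknown or untested is made for them only; others in the source may bear on it.

Values in a functional assay on MT4 cells (Homo sapiens), read by MTT assay; on this read-out higher numbers stand for lower toxicity in this test and lower numbers for higher toxicity in this test
Compound 1 `C#C[C@]1(CO)OC(N2C=CC(N)NC2=O)[C@@H](O)[C@@H]1O` gives 1740 nM
Compound 2 `C#C[C@]1(CO)O[C@@H](n2cc(C)c(=O)[nH]c2=O)C[C@@H]1O` gives > 380000 nM
Compound 3 `C#C[C@]1(CO)O[C@@H](n2cc(CC)c(=O)[nH]c2=O)C[C@@H]1O` gives > 360000 nM

On these data alone, compound 3 gives > 360000 nM as a limit and not a number, so its exact place on the scale is unknown. Compound 2 gives > 380000 nM which is also a limit. Compound 1 gives 1740 nM as a true number, but it differs from compound 3 in more than one place and so offers no direct guide.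

The change followed here leads from compound 3 to compound 4 `C#C[C@]1(CO)O[C@@H](n2cc(Br)c(=O)[nH]c2=O)C[C@@H]1O` and puts bromo in place of ethyl on an aromatic carbon. Within the data shown here, the one measured step involving this group is a step that the two limits leave unreadable from compound 2 to compound 3 and it therefore gives no size to carry over. It does show that both the methyl and the ethyl compound ended at limits, so no clear step in either direction is expected in this assay and another limit would be no surprise. The expected change is an at least 1.2-fold lower number from compound 3 to compound 4 (0.07 log units; that floor lies within the scatter) and this remains only an estimate. Compound 4 is expected at 300000 nM with an estimated range from 80000 nM to 400000 nM in this assay once it is measured.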

Compound 4, half-maximal cytotoxic concentration: > 100000 nM
Compound 4: only a limit was reported; the forecaster's own chance of this, stated with the estimate: 75%; the middle value is on the limit's open side.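

In this assay compound 4 gives > 100000 nM, which is a limit and not a number. Among these compounds, compound 2 and compound 3 also stand only as limits, so no step among compound 2, compound 3 and compound 4 can be read. The compounds shown leave open whether bromo, methyl or ethyl on the aromatic carbon gives any real difference in this assay.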